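Bromo in place of chloro at the same aromatic position

This account rests on a few compounds, and the source may have more. Where it says the series, first, only, none or still open, it means among the compounds named here.

Measured so far in a functional assay on cells (Erythrocyte, Rattus norvegicus) for inhibition, read by hemolysis, with a stated time of 1 h; a higher number here means a weaker inhibitor, a lower number a stronger inhibitor:
- compound 1 `COc1cc(OC)c(OC)cc1/C=C/C(=O)c1ccc([N+](=O)[O-])cc1` gives 2.34 ug/mL
- compound 2 `COc1cc(OC)c(OC)cc1/C=C/C(=O)c1ccc(F)cc1` gives 2.22 ug/mL
- compound 3 `COc1cc(OC)c(OC)cc1/C=C/C(=O)c1ccc(Cl)cc1` gives 2.3 ug/mL

On the numbers shown, compound 3 is the second highest of the three, but this says little: a 1.0-fold lower number from compound 1 to compound 3 (0.01 log units; within the scatter) and a 1.0-fold higher number from compound 2 to compound 3 (0.02 log units; within the scatter) are both within the scatter, so the three compounds cannot be told apart in this assay.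

Compound 4 `COc1cc(OC)c(OC)cc1/C=C/C(=O)c1ccc(Br)cc1` has not yet been measured. It differs from compound 3 by bromo in place of chloro on an aromatic carbon. Going by the values given here, the steps that bear on this are the three swaps already made at the very same aromatic carbon: a 1.1-fold lower number from compound 1 to compound 2 (0.02 log units; within the scatter), a 1.0-fold lower number from compound 1 to compound 3 (0.01 log units; within the scatter) and a 1.0-fold higher number from compound 2 to compound 3 (0.02 log units; within the scatter). Nitro, fluoro and chloro at that carbon gave numbers that sit on top of one another, with no step beyond the scatter. Nothing is known directly about bromo, but the change from chloro to bromo is of the same kind as those already tried, and the step of no change at the digits printed from compound 3 to compound 4 (within the scatter) is therefore expected to be none beyond the scatter. Compound 4 is estimated to give 2.3 ug/mL in this assay, with a range from 1.4 ug/mL to 3.8 ug/mL.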

Compound 4, half-maximal inhibitory concentration: 2.3 ug/mL
Compound 4: the middle estimate sits on the measured number at the digits printed, and the stated range covers the measured number.
By their numbers in this assay, from the lowest: compounds 2, 3, 4 and 1 (each within the scatter of the next).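

In this assay the swap to bromo at this aromatic carbon gives no change at the digits printed from compound 3 to compound 4 (within the scatter) and the comparisons with the other two compounds give a 1.0-fold higher number from compound 2 to compound 4 (0.02 log units; within the scatter) and a 1.0-fold lower number from compound 1 to compound 4 (0.01 log units; within the scatter) so bromo cannot be told apart from chloro, fluoro or nitro here. The earlier compounds had tried only fluoro and chloro among the halogens, whereas the set now runs on to bromine and the flat picture still holds: among these four compounds, no step at this carbon, para to a large group, lies beyond the scatter. No supporting data are available to explain why these four groups give numbers so close together.

Going by these compounds, whether this flat picture extends to very different groups at the same carbon, such as an amine, a carboxylic acid or a longer chain, remains open. The rest of the shared core is identical in all four compounds, so these results also cannot say what would happen if one of its methoxy groups were replaced by a hydroxyl group.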